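Acetyl in Place of Ethyl: An Expected Shift in Binding

A few compounds are considered here, and "the series" means these few. Any claim that something is new, unique, unknown or untested is made for them only; others in the source may bear on it.

Of the compounds shown here, two have been measured in an assay on membranes from brain (strain Sprague-Dawley) for displacement of a labelled ligand from metabotropic glutamate receptor 5 (Rattus norvegicus), read by scintillation counting, with a stated time of 60 min; on this read-out lower numbers stand for stronger inhibition and higher numbers for weaker inhibition. Compound 1 `COc1cc(C#N)cc(C#Cc2cccc(C)n2)c1` gives 1.29 nM in this assay. Compound 2 `CCc1cccc(C#Cc2cccc(C#N)c2)n1` gives 3.4 nM in this assay, the higher of the two numbers; its nearest neighbour, compound 1, sits lower by a margin beyond the usual scatter. Compound 3 `CC(=O)c1cccc(C#Cc2cccc(C#N)c2)n1` has not yet been measured. It differs from compound 2 by acetyl in place of ethyl on an aromatic carbon. Within the data shown here, no step between measured compounds matches this change, so any expectation rests only on the values of compound 2 and compound 1 and on the change itself. The step is expected to be a modest one toward weaker inhibition a 2.4-fold higher number from compound 2 to compound 3 (0.37 log units; beyond the scatter), near the edge of the scatter rather than far beyond it. Compound 3 is estimated at 8 nM, with a range from 2 nM to 30 nM.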

Compound 3, inhibition constant: 114 nM
Compound 3: middle estimate off by 14-fold (1.15 log units), on the low side, and the stated range ends below it.
By their numbers in this assay, from the lowest: compound 1; then compound 2; then compound 3.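

In this assay the exchange of ethyl for acetyl on this aromatic carbon, next to the ring nitrogen, gives a 34-fold higher number from compound 2 to compound 3 (1.53 log units; beyond the scatter) and so is a large step beyond the scatter. The earlier compounds shown here offered no step at this position, and this one shows that binding here is highly sensitive to the group it carries, even though the change is only 2 heavy atoms leaving and 3 entering, with a carbonyl oxygen among them. No measurement in hand accounts for the size of this step.

From the compounds shown here alone, with only ethyl and acetyl compared here, it remains open whether an amine, a hydroxyethyl group or a longer chain such as propyl would stay close to compound 2 or fall toward compound 3. Going by these compounds, whether acetyl would cost as much on the core of compound 1 is also open.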